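Bromo for nitro on the aryl ring of the dienone series

The compounds below may be only part of what the source reports. "The series", "measured", "known", "first", "only" and "open" are said of these compounds alone.

The two measured compounds share the same core and differ only in the aromatic substituent. Compound 1 `CC1=C(/C=C/C(=O)/C=C/c2ccc(Br)cc2)C(C)(C)CCC1` carries a bromo group; in a functional assay on MCF7 cells (Homo sapiens) for cytotoxicity, read by sulforhodamine B assay, with a stated time of 48 h (a higher number here means a weaker inhibitor, a lower number a stronger inhibitor), compound 1 gives 20100 nM. Compound 2 `CC1=C(/C=C/C(=O)/C=C/c2ccccc2[N+](=O)[O-])C(C)(C)CCC1` carries a nitro group, and in this assay compound 2 gives 10100 nM. Compound 2 has the lowest of the two numbers, and its nearest neighbour is compound 1, whose number is within the scatter of it; the two values therefore show no separation that can be trusted.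

Compound 3 `CC1=C(/C=C/C(=O)/C=C/c2ccccc2Br)C(C)(C)CCC1` is not yet measured. Relative to compound 2 the change is bromo in place of nitro on an aromatic carbon. Among the measured compounds shown here, no step of this kind is available, so the size of the step can only be guessed. Given that compound 1, which also carries a bromo group, gives 20100 nM, and that compound 2 gives 10100 nM, the expected step is small and probably toward a higher number, but not clearly beyond the scatter. For compound 3 the expected step is a 1.5-fold higher number from compound 2 to compound 3 (0.17 log units; within the scatter). Compound 3 is estimated at 15000 nM, with a range from 6000 nM to 40000 nM.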

Compound 3, half-maximal inhibitory concentration: 20700 nM
The estimate for compound 3 lay 1.4-fold (0.14 log units) below the measured number; the range from low to high includes it.
By their numbers in this assay, from the lowest: compounds 2, 1 and 3 (each within the scatter of the next, the first and the last beyond it).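

In this assay, the change on the aromatic carbon ortho to a large group now has a measured size: bromo in place of nitro gives a 2.0-fold higher number from compound 2 to compound 3 (0.31 log units; beyond the scatter), a modest step and the only one in the series that lies beyond the scatter. The comparison of 2-bromophenyl with 4-bromophenyl gives a 1.0-fold higher number from compound 1 to compound 3 (0.01 log units; within the scatter), so the two bromo compounds cannot be told apart and the placing of the bromo group on the aryl ring makes no readable difference in this pair. Nothing available accounts for the separation between nitro and bromo, which rests on this single pair of compounds and stands close to the edge of the scatter.

Still open, on these data alone, is whether the step seen here is specific to bromo or would recur with an amine, a methoxy group or a carboxylic acid on the same aromatic carbon, and whether any of these would give a number further from that of compound 2 than bromo does. The compounds shown also leave open how a ring bearing only hydrogen at this carbon would compare with compound 2 and compound 3.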